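A few compounds are considered here, and "the series" means these few. Any claim that something is new, unique, unknown or untested is made for them only; others in the source may bear on it.

Compound 1 `C[C@H]1CC(Cl)=C([Si](C)(C)C)[C@@H](C2CCCCC2)O1` gives 31000 nM in a functional assay on SW1573 cells (Homo sapiens) for antiproliferative activity; a lower number here means a stronger inhibitor of growth, a higher number a weaker inhibitor of growth. In this assay compound 2 `CC[C@H]1CC(Cl)=C([Si](C)(C)C)[C@@H](C2CCCCC2)O1` gives 49000 nM. Compound 3 `C[C@@H]1O[C@H](C2CCCCC2)C([Si](C)(C)C)=C(Cl)[C@H]1C` gives 41000 nM in this assay, the second highest of the three numbers and within the scatter of both compound 1 and compound 2. The two measured steps, a 1.6-fold higher number from compound 1 to compound 2 (0.20 log units; within the scatter) and a 1.3-fold higher number from compound 1 to compound 3 (0.12 log units; within the scatter), each add a methyl and stay within the scatter. Compound 4 `C[C@@H]1O[C@H](CCC=C(Br)Br)C([Si](C)(C)C)=C(Cl)[C@H]1C` differs from compound 3 by 4,4-dibromobut-3-en-1-yl in place of cyclohexyl on a saturated ring carbon. Among the measured compounds shown here, no measured step exchanges this group, so the measured steps bear on it only indirectly, and the expected step of a 1.0-fold lower number from compound 3 to compound 4 (0.01 log units; within the scatter) is none beyond the scatter, with wide uncertainty. Compound 4 is therefore estimated at 40000 nM in this assay, between 10000 nM and 150000 nM.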

Compound 4, concentration for total growth inhibition: 43000 nM
For compound 4 the middle estimate is 1.1-fold (0.03 log units) below the measured one; measured number inside the range.
By their numbers in this assay, from the lowest: compounds 1, 3, 4 and 2 (each within the scatter of the next).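

At this saturated ring carbon, next to the ring oxygen, 4,4-dibromobut-3-en-1-yl in place of cyclohexyl gives a 1.0-fold higher number from compound 3 to compound 4 (0.02 log units; within the scatter) in this assay. The earlier steps shown here only added a methyl, whereas this one replaces a ring of carbon with an open chain bearing two bromines and a double bond, at an equal heavy-atom count, and still stays within the scatter. Nothing measured here accounts for this result. As far as these compounds go, whether a chain ending in an amine or a carboxylic acid at this position would move the number beyond the scatter remains open.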